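This account rests on a few compounds, and the source may have more. Where it says the series, first, only, none or still open, it means among the compounds named here.

Measured compounds:
compound 1 `CC(=O)Nc1ccc(OC(=S)Nc2ccc(Nc3ccc(C(F)(F)F)cc3)cc2)cc1` – 9.05
compound 2 `CC(=O)Nc1ccc(OC(=S)Nc2ccc(Sc3ccc(C(F)(F)F)cc3)cc2)cc1` – 9.02
compound 3 `Oc1ccc(OC(=S)Nc2ccc(Nc3ccc(C(F)(F)F)cc3)cc2)cc1` – 9.23

In a physicochemical assay for acid dissociation, compound 2 gives the lowest of the three numbers, though its nearest neighbour compound 1 lies only 9.05 and compound 3, the furthest, 9.23, both within the scatter of compound 2. Among the measured compounds shown here, the only step between compounds that differ in one place, a number 0.18 log units higher from compound 1 to compound 3 (within the scatter), shows that exchanging the group at the far end of the shared core barely moves the read-out.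

Compound 4 `CC(=O)Nc1ccc(OC(=S)Nc2ccc(Sc3ccc([N+](=O)[O-])cc3)cc2)cc1` differs from compound 2 by nitro in place of trifluoromethyl on an aromatic carbon. For the measured compounds named here, no measured step touches this ring; the one recorded step, a number 0.18 log units higher from compound 1 to compound 3 (within the scatter), sits at the opposite end of the molecule and was within the scatter, and the comparison of compound 1 with compound 2 likewise shows only a difference inside the scatter. The precedent therefore points to small movements in this assay for changes at the outer rings of the shared core, and a step of a number 0.17 log units lower from compound 2 to compound 4 (within the scatter) is expected, most likely toward a lower read-out but not clearly beyond the scatter. Compound 4 is accordingly estimated at 8.85, within 8.45 to 9.25.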

Compound 4, acid dissociation constant: 8.99
Beside the measured number, compound 4's estimate is 0.14 log units below it; low and high end bracket the measured number.
By their numbers in this assay, from the lowest: compounds 4, 2, 1 and 3 (each within the scatter of the next).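

In this assay, putting 4-nitrophenyl in place of 4-(trifluoromethyl)phenyl gives a number 0.03 log units lower from compound 2 to compound 4 (within the scatter), and this is the only step shown that touches this outer ring. The earlier compounds shown here all carried trifluoromethyl here and could say nothing about this position, whereas this pair shows that one exchange on an aromatic carbon, para to a large group, with different atoms and with hydrogen-bond acceptors entering where the leaving group had none, stays inside the scatter of the acid dissociation read-out. Nothing given here speaks to why the read-out responds so little to this exchange.

From the compounds shown here alone, a single exchange cannot show whether this holds for the position in general, and it remains open whether an amine or a carboxylic acid on this ring would also stay within the scatter. Among the compounds shown here, the exchange is also seen only with the acetamido group and the sulfur of compound 2, so whether it would behave alike with the hydroxy group and the nitrogen link of compound 3 stays unknown.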